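A few compounds are considered here, and "the series" means these few. Any claim that something is new, unique, unknown or untested is made for them only; others in the source may bear on it.

Compound 1 `Cc1ccc(-c2nnc([S+](C)[O-])n2C)cc1` and compound 2 `Cc1ccc(-c2nnc(S(C)(=O)=O)n2C)cc1` share one core and differ only by a group of 4 heavy atoms (1 carbon, 2 oxygen, 1 sulfur; no ring) in place of a group of 3 heavy atoms (1 carbon, 1 oxygen, 1 sulfur; no ring), on an aromatic carbon. In a functional assay on the whole organism for antagonist activity, with Mus musculus as the target (a higher number here means that more compound is needed for the effect, a lower number that less compound is needed), compound 1 gives > 200 mg/kg, which is a limit of the assay and not a number. In this assay compound 2 likewise gives > 200 mg/kg, again a limit. The step that the two limits leave unreadable from compound 1 to compound 2 therefore cannot be read, because of the limit of > 200 mg/kg in this assay, at which 2 of the 3 values shown sit. Compound 3 `Cn1c(-c2ccccc2F)nnc1[S+](C)[O-]` rests on another core; how the two cores differ is not broken down here. In this assay, within the data shown here, compound 3 gives 57.9 mg/kg, the only actual number among the three values. Compound 4 `Cn1c(-c2ccccc2F)nnc1S(C)(=O)=O` has not yet been measured; it differs from compound 3 by a group of 4 heavy atoms (1 carbon, 2 oxygen, 1 sulfur; no ring) in place of a group of 3 heavy atoms (1 carbon, 1 oxygen, 1 sulfur; no ring), on an aromatic carbon, the same change as that between compound 1 and compound 2, at an identically described place. Among the measured compounds shown here, since the one measured instance of this change is a step that the two limits leave unreadable from compound 1 to compound 2 and gives no readable size, the expected step is a 1.2-fold higher number from compound 3 to compound 4 (0.08 log units; within the scatter), close to no change, with wide uncertainty. Compound 4 is accordingly estimated at 70 mg/kg, within a range from 25 mg/kg to 200 mg/kg.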

Compound 4, dose for half-maximal effect: > 100 mg/kg
Compound 4 gave a limit, no number; the forecaster's own chance of this, stated with the estimate: 30%; middle value at least 1.4-fold (0.15 log units) away from the limit.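

In this assay compound 4 gives > 100 mg/kg, which is a limit of the assay and not a number. Going by these compounds, replacing the group carried by compound 3 with methylsulfonyl gives an at least 1.7-fold higher number from compound 3 to compound 4 (0.23 log units; that floor lies within the scatter), so the true size of this step stays unknown: it may lie within the usual scatter of the measurement or well beyond it. Whether the change does the same on both cores cannot be said, because the step from compound 1 to compound 2 cannot be read: the limit of > 200 mg/kg in this assay, at which 2 of the 4 values shown sit.

The compounds shown carry only these two sulfur-containing groups on the aromatic carbon of the five-membered ring, so the effect of an amine or a longer chain at that place remains open. Among these compounds, also open is how a carboxylic acid there would compare with compound 3, the only compound here with an actual number.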